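The source may report more compounds than this note shows. Statements on the series, on what has been measured and on what is new or still open speak of the compounds shown alone.

Three analogues built on one shared core have been measured in a functional assay on A549 cells (Homo sapiens) for cytotoxicity, read by MTT assay, with a stated time of 48 h; on this read-out higher numbers stand for weaker inhibition and lower numbers for stronger inhibition. Compound 3 `COc1c(OCCCCN2CCN(C)CC2)cc(O)c2c(=O)cc(-c3ccccc3)oc12` gives 1500 nM, the lowest of the two numbers reported. Compound 1 `COc1c(OCCCCNCc2ccccc2)cc(O)c2c(=O)cc(-c3ccccc3)oc12` gives 4590 nM, which is a 3.1-fold lower number from compound 1 to compound 3 (0.49 log units; beyond the scatter). Compound 2 `COc1c(OCc2nc3ccccc3[nH]2)cc(O)c2c(=O)cc(-c3ccccc3)oc12` reaches only a limit of the assay, > 100000 nM, and the limit of > 100000 nM in this assay, at which 1 of the 3 values shown sits, records it as such. Compound 4 `COc1c(OCc2cnoc2C)cc(O)c2c(=O)cc(-c3ccccc3)oc12` has not yet been measured; it differs from compound 3 by 5-methyl-1,2-oxazol-4-yl in place of 3-(4-methylpiperazin-1-yl)propyl on a saturated chain carbon bound to an oxygen on an aromatic ring. The step of an at least 21-fold higher number from compound 1 to compound 2 (1.33 log units; beyond the scatter) bears directly on this change, where an amine-bearing chain likewise gave way to a small aromatic ring on the carbon bound to the aromatic oxygen, and an at least 66-fold lower number from compound 2 to compound 3 (1.82 log units; beyond the scatter) shows the same in reverse. A large rise in number is therefore expected for compound 4, estimated at 60000 nM with a range from 15000 nM to 200000 nM, which would mean a 40-fold higher number from compound 3 to compound 4 (1.60 log units; beyond the scatter).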

Compound 4, half-maximal inhibitory concentration: > 100000 nM
Compound 4: a limit, no number (the forecaster's own chance of this, stated with the estimate: 50%); at least 1.6-fold (0.22 log units) between middle value and limit.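

The change gives an at least 66-fold higher number from compound 3 to compound 4 (1.82 log units; beyond the scatter) and an at least 21-fold higher number from compound 1 to compound 4 (1.33 log units; beyond the scatter), so the loss seen with the 1H-benzimidazol-2-yl group of compound 2 is not confined to that group. Compound 4 also gives a limit and not a number, so a second aromatic ring on this saturated chain carbon ends at the same limit: the limit of > 100000 nM in this assay, at which 2 of the 4 values shown sit. The step from compound 2 to compound 4 cannot be read, which leaves these two compounds unordered.

On these data alone, whether a plain butyl chain without an amine, or a shorter chain ending in 4-methylpiperazin-1-yl, would give a number or a limit in this assay stays open. So does whether an aromatic ring set further along a chain from the oxygen would do the same.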